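A few compounds are considered here, and "the series" means these few. Any claim that something is new, unique, unknown or untested is made for them only; others in the source may bear on it.

Compound 1 `CCc1ccccc1N(CC(=O)NCc1ccc(Cl)cc1)S(=O)(=O)c1ccc(C)cc1` gives 10 nM in an assay on CHO cells for displacement of a labelled ligand from prostaglandin E2 receptor EP1 subtype (Homo sapiens); a lower number here means a stronger inhibitor, a higher number a weaker inhibitor.
Compound 2 `Cc1ccc(S(=O)(=O)N(CC(=O)NCc2ccc(Cl)cc2)c2ncccc2C)cc1` gives 794 nM in this assay.

Among these two numbers, compound 1 stands lowest, and the only step measured, a 79-fold higher number from compound 1 to compound 2 (1.90 log units; beyond the scatter), was large. Compound 3 `CCn1nccc1N(CC(=O)NCc1ccc(Cl)cc1)S(=O)(=O)c1ccc(C)cc1` is not yet measured; it differs from compound 1 in one place: 1-ethyl-1H-pyrazol-5-yl in place of 2-ethylphenyl on a sulfonamide nitrogen. The change from compound 1 to compound 2 is the only one that bears on this step, since it also exchanges the same group on the sulfonamide nitrogen for a heteroaromatic ring. A similar weakening is therefore expected here, though its size is uncertain. Compound 3 is estimated at 300 nM (range 60 nM to 1500 nM), an expected step of a 30-fold higher number from compound 1 to compound 3 (1.48 log units; beyond the scatter).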

Compound 3, inhibition constant: 158 nM
Beside the measured number, compound 3's estimate is 1.9-fold (0.28 log units) above it; the range from low to high includes it.
By their numbers in this assay, from the lowest: compound 1; then compound 3; then compound 2.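

On the sulfonamide nitrogen, a second heteroaromatic ring, 1-ethyl-1H-pyrazol-5-yl, also gives a weaker inhibitor than 2-ethylphenyl, with a 16-fold higher number from compound 1 to compound 3 (1.20 log units; beyond the scatter), so the loss is not confined to 3-methylpyridin-2-yl. The two replacements are not equivalent, as a 5.0-fold lower number from compound 2 to compound 3 (0.70 log units; beyond the scatter) shows that the entering ring affects the result and not only the departure of 2-ethylphenyl. No supporting measurement is available to explain either step. As far as these compounds go, it remains open how a phenyl ring carrying a propyl chain, a methoxy group or an amine would behave at this position. Whether any heteroaromatic ring here can match compound 1 also remains unresolved.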